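The compounds below may be only part of what the source reports. "The series", "measured", "known", "first", "only" and "open" are said of these compounds alone.

Of the compounds shown here, three sharing one core have been tested in a functional assay on A498 cells (Homo sapiens) for cytotoxicity, read by sulforhodamine B assay, with a stated time of 48 h; on this read-out higher numbers stand for weaker inhibition of growth and lower numbers for stronger inhibition of growth. Compound 1 `ClCc1ccccc1Cn1cnc2c(Cl)nc(Cl)nc21` gives 4780 nM in this assay. Compound 2 `ClCc1ccccc1Cn1cnc2c(Cl)ncnc21` gives 32400 nM in this assay, and compound 3 `ClCc1cccc(Cn2cnc3c(Cl)ncnc32)c1` gives 31600 nM in this assay. The values of compound 2 and compound 3 lie within the usual scatter of each other, so no order can be drawn between them. Compound 1 differs from compound 2 in one place: chloro in place of hydrogen on an aromatic carbon. That single change gave a 6.8-fold lower number from compound 2 to compound 1 (0.83 log units; beyond the scatter).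

Compound 4 `ClCc1cccc(Cn2cnc3c(Cl)nc(Cl)nc32)c1` has not yet been measured. It stands to compound 3 as compound 1 stands to compound 2, through the same change: chloro in place of hydrogen on an aromatic carbon. The surroundings of the changed position are described in the same words for both pairs, so it is the same change, not merely one of the same kind. How the core of compound 3 differs from the core of compound 2 is not broken down here; the two contain the same atoms joined differently.

The expected step from compound 3 to compound 4 is a 6.3-fold lower number from compound 3 to compound 4 (0.80 log units; beyond the scatter) in this assay, set beside the earlier one of a 6.8-fold lower number from compound 2 to compound 1 (0.83 log units; beyond the scatter). Among the measured compounds shown here, this expectation rests on compound 3 starting from 31600 nM, a value within the scatter of compound 2, and on the single earlier example of the same change. For the measured compounds named here, with only one prior example, the range is kept wide. Compound 4 is therefore estimated to give 5000 nM in this assay, likely between 2000 nM and 13000 nM.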

Compound 4, concentration for total growth inhibition: 6600 nM
The estimate for compound 4 lay 1.3-fold (0.12 log units) below the measured number; measured number inside the range.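

Placing chloro instead of hydrogen on the aromatic carbon between two ring nitrogen atoms again strengthened growth inhibition, with a 4.8-fold lower number from compound 3 to compound 4 (0.68 log units; beyond the scatter) in this assay. The size of this step matches that of the earlier one, so in this series the change carried over from one core to the other, in direction and in size: the same change on two cores in this assay, a 6.8-fold lower number (0.83 log units; beyond the scatter) from compound 2 to compound 1 and a 4.8-fold lower number (0.68 log units; beyond the scatter) from compound 3 to compound 4, 1.4-fold (0.15 log units) apart, within the scatter of two such steps
Among the compounds shown here, this does not show why the chloro group has this effect, and with only two cores, which contain the same atoms joined differently, and a single cell assay, it offers no rule for cores beyond these two.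

The compounds shown leave open what other groups on that same aromatic carbon would do, for example an amine, a methoxy group or a longer chain, since chloro and hydrogen are the only two seen there. They also leave open whether the step of similar size seen in this assay would appear on other cell lines, or whether a core carrying some other group in place of the chloromethyl group would respond to the change in the same way.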